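Adding a Third Methoxy to Compound 3

The compounds below may be only part of what the source reports. "The series", "measured", "known", "first", "only" and "open" are said of these compounds alone.

Measured so far in a functional assay on MCF7 cells (Homo sapiens) for antiproliferative activity, read by sulforhodamine B assay, with a stated time of 48 h; on this read-out lower numbers stand for stronger inhibition of growth and higher numbers for weaker inhibition of growth:
Compound 1, `O=C(NCc1cn(Cc2ccc(Cl)cc2)nn1)c1cn(-c2ccccc2)nc1-c1ccccc1`, gives > 100000 nM, a limit of the assay and not a number.
Compound 2, `COc1ccc(Cn2cc(CNC(=O)c3cn(-c4ccccc4)nc3-c3ccccc3)nn2)cc1OC`, gives 12600 nM.
Compound 3, `COc1cc(Cn2cc(CNC(=O)c3cn(-c4ccccc4)nc3-c3ccccc3)nn2)cc(OC)c1`, gives 2400 nM.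

Compound 3 holds the lowest of the two numbers; the gap between those two numbers is a 5.3-fold lower number from compound 2 to compound 3 (0.72 log units; beyond the scatter), and compound 1 sits only at a limit (the limit of > 100000 nM in this assay, at which 1 of the 3 values shown sits). Compound 4, `COc1cc(Cn2cc(CNC(=O)c3cn(-c4ccccc4)nc3-c3ccccc3)nn2)cc(OC)c1OC`, differs from compound 3 by methoxy in place of hydrogen on an aromatic carbon. For the measured compounds named here, the steps that bear on this change all alter the same ring: an at least 7.9-fold lower number from compound 1 to compound 2 (0.89 log units; beyond the scatter), an at least 41-fold lower number from compound 1 to compound 3 (1.61 log units; beyond the scatter) and a 5.3-fold lower number from compound 2 to compound 3 (0.72 log units; beyond the scatter), each lowering the number as methoxy groups replaced chloro or moved. Going by the values given here, a further modest lowering is therefore expected, though no step adds a third methoxy. Compound 4 is expected at 800 nM, between 200 nM and 3000 nM, a step of a 3.0-fold lower number from compound 3 to compound 4 (0.48 log units; beyond the scatter).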

Compound 4, concentration for 50% growth inhibition: > 100000 nM
Compound 4 ended at the assay's limit; the forecaster's own chance of this, stated with the estimate: 2%; middle value at least 120-fold (2.09 log units) from the limit.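

In this assay, unlike the earlier changes to this ring, adding methoxy ortho to two methoxy groups and para to a large group raises the number sharply, with an at least 41-fold higher number from compound 3 to compound 4 (1.61 log units; beyond the scatter). The 3,4,5-trimethoxyphenyl ring also compares poorly with the 3,4-dimethoxyphenyl ring, with an at least 7.9-fold higher number from compound 2 to compound 4 (0.89 log units; beyond the scatter), so more methoxy groups did not mean a lower number here. Compound 4 and compound 1 both end at a limit of the assay, so the step between them cannot be read: the limit of > 100000 nM in this assay, at which 2 of the 4 values shown sit.

Going by these compounds, whether a hydroxy or ethoxy group at this position would also end at the limit stays open. So does whether a lone methoxy there, without the two flanking methoxy groups, would do the same.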